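The compounds below may be only part of what the source reports. "The series", "measured", "known", "first", "only" and "open" are said of these compounds alone.

Measured in an ADME assay on HeLa cells (Homo sapiens) for cytotoxicity, read by XTT assay, with a stated time of 3 days; on this read-out lower numbers stand for higher toxicity in this test and higher numbers for lower toxicity in this test:
Compound 1 `C1=C(/C=C/c2cccnc2)COc2ccccc21`: 75000 nM
Compound 2 `O=c1c(/C=C/c2ccccn2)coc2ccccc12`: > 200000 nM (a limit of the assay, not a number)

Compound 2 stands at the top of the measurable range, and its true value is not known. The evidence on the two compounds reads: the limit of > 200000 nM in this assay, at which 1 of the 2 values shown sits. Compound 3 `O=c1c(/C=C/c2ccccn2)coc2ccc(Cl)cc12` is the next compound to be tested, and it differs from compound 2 by chloro in place of hydrogen on an aromatic carbon. Among the compounds with values here, no measured pair of compounds shows this change, so the expectation in this assay is a tentative one. A small move toward lower numbers is expected, and it may stay within the usual scatter. The expected change is an at least 1.3-fold lower number from compound 2 to compound 3 (0.12 log units; that floor lies within the scatter). Compound 3 may also be reported only as a limit. The estimated value for compound 3 is 150000 nM, with an expected range from 60000 nM to 350000 nM.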

Compound 3, half-maximal cytotoxic concentration: > 50000 nM
Compound 3 ended at the assay's limit; the forecaster's own chance of this, stated with the estimate: 50%; the middle value is on the limit's open side.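

Compound 2 and compound 3 are both reported only as limits, not as numbers, so the step between them cannot be read. The compounds shown leave open whether chloro in place of hydrogen on an aromatic carbon changes the half-maximal cytotoxic concentration at all, and in which direction.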